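Para-Substituent Swap on a Benzimidazole Thioether Ketone Series

The compounds below may be only part of what the source reports. "The series", "measured", "known", "first", "only" and "open" are said of these compounds alone.

Measured so far:
compound 1 `O=C(CSc1nc2ccccc2[nH]1)c1ccc(Br)cc1` gives 43000 nM in a functional assay on HT-29 cells (Homo sapiens) for inhibition, read by WST assay, with a stated time of 48 h; on this read-out higher numbers stand for weaker inhibition and lower numbers for stronger inhibition
compound 2 `O=C(CSc1nc2ccccc2[nH]1)c1ccc(F)cc1` gives 78700 nM in this assay

Compound 2 gives the highest of the two numbers, and compound 1 sits nearest, a gap described by a 1.8-fold higher number from compound 1 to compound 2 (0.26 log units; within the scatter). Compound 3 `O=C(CSc1nc2ccccc2[nH]1)c1ccc([N+](=O)[O-])cc1` differs from compound 2 by nitro in place of fluoro on an aromatic carbon. Within the data shown here, the only measured step that bears on this change is a 1.8-fold higher number from compound 1 to compound 2 (0.26 log units; within the scatter), and it lies within the scatter. No step beyond the scatter is therefore expected in this assay, in either direction. Compound 3 is estimated at 60000 nM, with a range from 15000 nM to 200000 nM, an expected step of a 1.3-fold lower number from compound 2 to compound 3 (0.12 log units; within the scatter).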

Compound 3, half-maximal inhibitory concentration: 57000 nM
The estimate for compound 3 lay 1.1-fold (0.02 log units) above the measured number, and the stated range covers the measured number.
By their numbers in this assay, from the lowest: compounds 1, 3 and 2 (each within the scatter of the next).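

Swapping in nitro, with three heavy atoms and two hydrogen-bond acceptors where fluoro has one heavy atom and none, gives a 1.4-fold lower number from compound 2 to compound 3 (0.14 log units; within the scatter) and a 1.3-fold higher number from compound 1 to compound 3 (0.12 log units; within the scatter) in this assay with neither step leaving the scatter. Bromo, fluoro and nitro on this aromatic carbon, para to a large group, therefore give numbers that cannot be told apart here. Nothing available explains this result.

On these data alone, whether an amine, a carboxylic acid or a longer chain in this place would move the number beyond the scatter remains open.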